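The source may report more compounds than this note shows. Statements on the series, on what has been measured and on what is new or still open speak of the compounds shown alone.

Among the measured compounds shown here, measured compounds so far: compound 1 `Clc1ccc(C2=CC3CNCC(C2)C3)cn1` gives 6.2 nM in an in vitro assay on SH-SY5Y cells for displacement of a labelled ligand from Neuronal acetylcholine receptor; alpha3/beta4 (Homo sapiens); on this read-out lower numbers stand for stronger inhibition and higher numbers for weaker inhibition; compound 2 `COc1cc(C2=CC3CNCC(C2)C3)cnc1Cl` gives 7 nM; compound 3 `C1=C(c2cccnc2)CC2CNCC1C2` gives 12 nM.

Compound 1 holds the lowest of the three numbers, yet both neighbours sit within the scatter of it: a 1.1-fold higher number from compound 1 to compound 2 (0.05 log units; within the scatter) and a 1.9-fold higher number from compound 1 to compound 3 (0.29 log units; within the scatter). Compound 4 `CN1CC2C=C(c3ccc(Cl)nc3)CC(C2)C1` differs from compound 1 by methyl in place of hydrogen on an amine nitrogen in a ring. Neither measured step bears on this change; both concern the aromatic ring, and both stay within the scatter. The expectation for compound 4 therefore rests on compound 1 alone, with no direction indicated, so the step of a 1.6-fold higher number from compound 1 to compound 4 (0.21 log units; within the scatter) is an estimate carrying a wide range. Compound 4 is expected to give about 10 nM in this assay, between 3 nM and 40 nM.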

Compound 4, inhibition constant: 986 nM
Compound 4: middle estimate off by 99-fold (1.99 log units), on the low side, and the stated range ends below it.
By their numbers in this assay, from the lowest: compounds 1, 2 and 3 (each within the scatter of the next); then compound 4.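

In this assay, the amine nitrogen in the ring responds far more sharply than the aromatic ring to the changes shown: methyl in place of hydrogen gives a 160-fold higher number from compound 1 to compound 4 (2.20 log units; beyond the scatter), although only one carbon enters. By contrast, the aromatic changes in compound 2 and compound 3 stay within the scatter of compound 1. No measurement available here accounts for the size of this step.

Going by these compounds, whether ethyl, a longer chain or an acetyl group on that nitrogen would behave like methyl remains open. So does whether methyl there would produce a similar step from compound 2 or compound 3.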